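The source may hold more compounds than are shown below. What is called first, only, known or untested is meant among the compounds shown, and "the series" means these compounds.

Three measured compounds share the same core and differ only in the amine that sits on a saturated chain carbon three bonds along the chain from an oxygen on an aromatic ring. In a functional assay on A549 cells (Homo sapiens) for antiproliferative activity, read by MTT assay, with a stated time of 72 h (a higher number here means a weaker inhibitor, a lower number a stronger inhibitor), compound 1 `COc1cc2c(Nc3ccc(C#N)cc3)ncnc2cc1OCCCN(C)C` gives 60500 nM, and compound 2 `CCN(CC)CCCOc1cc2ncnc(Nc3ccc(C#N)cc3)c2cc1OC` gives 50600 nM. Compound 3 `COc1cc2c(Nc3ccc(C#N)cc3)ncnc2cc1OCCCN1CCC(CO)CC1` reaches only the limit of the assay, > 100000 nM, so no number is known for it. The steps of a 1.2-fold lower number from compound 1 to compound 2 (0.08 log units; within the scatter), an at least 1.6-fold higher number from compound 1 to compound 3 (0.21 log units; that floor lies within the scatter) and an at least 1.9-fold higher number from compound 2 to compound 3 (0.29 log units; that floor lies within the scatter) all stay within the scatter. Compound 4 `CCOC(=O)C1CCN(CCCOc2cc3ncnc(Nc4ccc(C#N)cc4)c3cc2OC)CC1` differs from compound 3 by ethoxycarbonyl in place of hydroxymethyl on a saturated ring carbon. Given that an at least 1.9-fold higher number from compound 2 to compound 3 (0.29 log units; that floor lies within the scatter) lay within the scatter, no step beyond it is expected here either. Compound 4 is therefore estimated at 100000 nM, with a range from 40000 nM to 250000 nM. The expected step is a number no higher from compound 3 to compound 4 (the limit leaves the size open).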

Compound 4, half-maximal inhibitory concentration: 89900 nM
Compound 4: middle estimate off by 1.1-fold (0.05 log units), on the high side, and the stated range covers the measured number.
By their numbers in this assay, from the lowest: compounds 2, 1 and 4 (each within the scatter of the next). At a limit, above all of these: compound 3.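

Replacing either open-chain amine with 4-(ethoxycarbonyl)piperidin-1-yl gives a measured number for a ring amine at this chain end, and it stays level with both: a 1.8-fold higher number from compound 2 to compound 4 (0.25 log units; within the scatter) and a 1.5-fold higher number from compound 1 to compound 4 (0.17 log units; within the scatter). Compound 3 remains at a limit of the assay, > 100000 nM. Going by these compounds, the step of an at least 1.1-fold lower number from compound 3 to compound 4 (0.04 log units; that floor lies within the scatter) therefore gives only a floor, and the true size of the change from hydroxymethyl to ethoxycarbonyl stays unknown. Still open, on these data alone, is how a carboxylic acid in place of ethoxycarbonyl, or a longer chain leading to the amine, would read here.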